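Methoxy in Place of Methyl on Two Related Cores

This account rests on a few compounds, and the source may have more. Where it says the series, first, only, none or still open, it means among the compounds named here.

Compound 1 `Cc1cccc(Nc2nccc(-c3ccc(Br)cc3)n2)c1` gives 74600 nM in a functional assay on HepG2 cells (Homo sapiens) for antiproliferative activity, read by MTT assay; a higher number here means a weaker inhibitor, a lower number a stronger inhibitor. Compound 2 `COc1cccc(Nc2nccc(-c3ccc(Br)cc3)n2)c1` gives 148000 nM. Compound 3 `Cc1cccc(Nc2nccc(-c3ccc(Cl)cc3Cl)n2)c1` gives 13200 nM, the lowest of the three numbers.

Compound 2 differs from compound 1 only by methoxy in place of methyl on an aromatic carbon, and that single change gave a 2.0-fold higher number from compound 1 to compound 2 (0.30 log units; within the scatter). The difference between the core of compound 1 and the core of compound 3 is not broken down here. Compound 4 `COc1cccc(Nc2nccc(-c3ccc(Cl)cc3Cl)n2)c1` now carries the same change on the core of compound 3: methoxy in place of methyl on an aromatic carbon. Because the earlier step, a 2.0-fold higher number from compound 1 to compound 2 (0.30 log units; within the scatter), stayed within the scatter, the step from compound 3 to compound 4 is expected to be of the same small size, a 2.0-fold higher number from compound 3 to compound 4 (0.29 log units; within the scatter). Compound 4 is therefore estimated at 26000 nM, most likely between 10000 nM and 70000 nM.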

Compound 4, half-maximal inhibitory concentration: 96900 nM
For compound 4 the middle estimate is 3.7-fold (0.57 log units) below the measured one, and the stated range ends below it.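

On the core of compound 3, methoxy in place of methyl gave a 7.3-fold higher number from compound 3 to compound 4 (0.87 log units; beyond the scatter), so the change did not stay small on this core. In this assay, the size of this step did not carry over from one core to the other: the same change on two cores in this assay, a 2.0-fold higher number (0.30 log units; within the scatter) from compound 1 to compound 2 and a 7.3-fold higher number (0.87 log units; beyond the scatter) from compound 3 to compound 4, 3.7-fold (0.57 log units) apart, beyond the scatter of two such steps. For the compounds shown here, these two pairs show only that the step differs between these two cores; they do not show which difference between the cores goes with the larger step, or how the change would behave on a third core.

Going by these compounds, it remains open how a hydroxyl, an amine or a longer chain in place of the methyl would behave on each core. Whether such groups would also give steps that differ between the cores is equally unknown.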